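Methyl to hydrogen on oxygen: notes toward compound 3

The source may hold more compounds than are shown below. What is called first, only, known or untested is meant among the compounds shown, and "the series" means these compounds.

Measured so far:
- compound 1, `CN/N=C/c1ccc2ccc(=O)oc2c1`, in a functional assay for inhibition of serine protease 1 (Homo sapiens), tested at 0.1 mM (a lower number here means a weaker effect, a higher number a stronger effect of the compound at the concentration tested), compound 1 gives 22.6%
- compound 2, `CO/N=C/c1ccc2ccc(=O)oc2c1`, in this assay compound 2 gives 25.5%

Among the measured compounds shown here, of the two numbers, the one for compound 2 is nominally the higher, but the only step that reaches it, a number 2.9 percentage points higher from compound 1 to compound 2 (within the scatter), keeps the pair within the scatter, so no order can be read from them.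

Compound 3, `O=c1ccc2ccc(/C=N/O)cc2o1`, is not yet measured. It differs from compound 2 as follows: hydrogen in place of methyl on an oxygen. For the measured compounds named here, the one measured step concerns the group on the double-bonded nitrogen, not the methyl on the oxygen, and it was itself within the scatter; nothing measured here bears directly on methoxy to hydroxy. On that basis no step beyond the scatter is expected, and a number 1.5 percentage points lower from compound 2 to compound 3 (within the scatter) is the estimated step. In this assay compound 3 is expected to give 24%, with a range from 10% to 40%.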

Compound 3, a percentage reported as inhibition, at one concentration (the size of the read-out at that concentration, not a potency): 20.3%
Estimate against measurement, compound 3: 3.7 percentage points above, within the range that was stated.
By their numbers in this assay, from the lowest: compounds 3, 1 and 2 (each within the scatter of the next).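

Removing the methyl from the oxygen on the double-bonded nitrogen gives the first direct reading of methoxy to hydroxy in this assay (a number 5.2 percentage points lower from compound 2 to compound 3 (within the scatter)), and at the concentration tested this methyl is not shown to matter. Hydroxy also stays within the scatter of methylamino (a number 2.3 percentage points lower from compound 1 to compound 3 (within the scatter)), so methylamino, methoxy and hydroxy on the double-bonded nitrogen cannot be placed in any order. No supporting data are available to explain this result.

Still open, from the compounds shown here alone, is whether a larger group on this oxygen, such as a benzyl group, a longer alkyl chain or a chain ending in a carboxylic acid, would give a step beyond the scatter. Going by these compounds, each compound was read at a single concentration, and the size of their effects at any other concentration remains unknown.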